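Oral tail flick activity in the purine glycinamide series

A few compounds are considered here, and "the series" means these few. Any claim that something is new, unique, unknown or untested is made for them only; others in the source may bear on it.

Measured so far in a functional assay on the whole organism (Tail, strain ICR) with Mus musculus as the target, in the tail flick test, with a stated time of 90 min, at a dose of 25 umol/kg by the oral route; on this read-out higher numbers stand for a stronger effect at the one dose given and lower numbers for a weaker effect:
compound 1 `C[C@H](NC(=O)CN(c1nc(Cl)nc2[nH]cnc12)C1CC1)C(=O)OCc1ccccc1`: 44.2%
compound 2 `N=C(N)NCCC[C@H](NC(=O)CN(c1nc(Cl)nc2[nH]cnc12)C1CC1)C(=O)O`: 27.6%
compound 3 `O=C(O)C[C@H](NC(=O)CN(c1nc(Cl)nc2[nH]cnc12)C1CC1)C(=O)O`: 25.1%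

Compound 3 gives the lowest of the three numbers; its gap to compound 2 lies within the scatter, while compound 1 stands beyond the scatter above it. Compound 4 `C[C@H](NC(=O)CN(c1nc(Cl)nc2[nH]cnc12)C1CC1)C(=O)O` is not yet measured. Its difference from compound 3 is hydrogen in place of carboxy on a saturated chain carbon, two bonds along the chain from an amide-type nitrogen and a carbonyl carbon. The only shown step at the same place, a number 2.5 percentage points lower from compound 2 to compound 3 (within the scatter), exchanged one side-chain group for another and stayed within the scatter. No shown step removes a group at this place outright, so the guidance is loose. Compound 1 carries the same side chain as compound 4 but differs elsewhere, and no step between them is shown; its value is only the upper end of what the series has given. The step of a number 4.9 percentage points higher from compound 3 to compound 4 (within the scatter) is expected to be small, most likely within the scatter. Compound 4 is therefore estimated at 30%, with a range from 15% to 46%.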

Compound 4, a percentage reported as activity, at one dose (the size of the read-out at that dose, not a potency): 43.5%
Estimate against measurement, compound 4: 13.5 percentage points below; the measured number falls inside the stated range.
By their numbers in this assay, from the lowest: compounds 3 and 2 (each within the scatter of the next); then compounds 4 and 1 (each within the scatter of the next).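

Hydrogen in place of carboxy on this saturated chain carbon gives a clear change in this assay (a number 18.4 percentage points higher from compound 3 to compound 4 (beyond the scatter)), and a hydrogen atom in place of the group of 6 heavy atoms gives a change of similar standing (a number 15.9 percentage points higher from compound 2 to compound 4 (beyond the scatter)). The earlier exchange of one of these groups for the other stayed within the scatter, so the position is sensitive to the change to the methyl side chain in a way that exchange could not show. At a different place, hydrogen in place of benzyl on an oxygen next to a carbonyl group leaves the read-out within the scatter (a number 0.7 percentage points lower from compound 1 to compound 4 (within the scatter)).

Still open, on these data alone, is how a longer chain, an amine or a hydroxymethyl group on this carbon would read, and whether a plain hydrogen in place of methyl would hold the level of compound 4. No measurement here bears on the reason for these steps.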